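The source may report more compounds than this note shows. Statements on the series, on what has been measured and on what is new or still open speak of the compounds shown alone.

Three measured compounds, all carrying a furan-2-yl group, set the scene. In a functional assay on MDA-MB-231 cells (Homo sapiens) for inhibition, read by CCK-8 assay and cell counting, with a stated time of 2 days (a higher number here means a weaker inhibitor, a lower number a stronger inhibitor), compound 1 `O=C(/C=C/c1ccco1)c1ccccc1OCC1CO1` gives 28700 nM, compound 2 `O=C(/C=C/c1ccco1)c1cccc(OCC2CO2)c1` gives 27800 nM and compound 3 `O=C(/C=C/c1ccco1)c1ccc(OCC2CO2)cc1` gives 47100 nM. Compound 3 therefore stands within the usual scatter of both compound 1 and compound 2, and the three cannot be ranked on these numbers. The next compound is compound 4 `O=C(/C=C/c1ccsc1)c1ccc(OCC2CO2)cc1`, which has thiophen-3-yl in place of furan-2-yl on a double-bonded chain carbon bound to a double-bonded chain carbon. Among the measured compounds shown here, no measured pair shows the effect of such an exchange, so the expectation in this assay rests only on the closeness of the three known values. No step beyond the scatter is expected in either direction. The estimated change is a 1.2-fold lower number from compound 3 to compound 4 (0.09 log units; within the scatter), which is expected to remain within that scatter. Compound 4 is estimated at 38000 nM, with an expected range from 16000 nM to 80000 nM.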

Compound 4, half-maximal inhibitory concentration: 11100 nM
Compound 4: middle estimate off by 3.4-fold (0.53 log units), on the high side; measured number outside the range, below it.
By their numbers in this assay, from the lowest: compound 4; then compounds 2, 1 and 3 (each within the scatter of the next).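

Replacing furan-2-yl with thiophen-3-yl on a double-bonded chain carbon bound to a double-bonded chain carbon gives the only step beyond the scatter among these compounds: in this assay there is a 4.2-fold lower number from compound 3 to compound 4 (0.63 log units; beyond the scatter) for this exchange. The earlier compounds shown here gave no sign that this place could change the number, and the exchange does so although the heavy-atom count, the hydrogen-bond counts and the net charge all stay the same. No measurement shown here accounts for the step.

As far as these compounds go, it remains open whether thiophen-2-yl or phenyl at this place would give a number like that of compound 4, which would help separate the effect of the sulfur from that of the point of attachment. From the compounds shown here alone, it is also open whether the exchange would give a similar step on the cores of compound 1 and compound 2.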